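The source may hold more compounds than are shown below. What is called first, only, known or untested is meant among the compounds shown, and "the series" means these compounds.

The measured compounds in a functional assay on DU-145 cells (Homo sapiens) for inhibition, read by trypan blue exclusion, with a stated time of 72 h; on this read-out lower numbers stand for stronger inhibition and higher numbers for weaker inhibition:

compound 1 `Cc1ccc(S(=O)(=O)c2cc3cnc(Nc4ccc5[nH]ccc5c4)nc3n(C)c2=O)cc1` — 750 nM
compound 2 `Cn1c(=O)c(S(=O)(=O)c2ccc(O)cc2)cc2cnc(Nc3ccc4[nH]ccc4c3)nc21` — 250 nM
compound 3 `Cn1c(=O)c(C(=O)Nc2ccc(F)cc2)cc2cnc(Nc3ccc4[nH]ccc4c3)nc21` — 5000 nM

Among these three numbers, compound 1 stands second highest. Its nearest neighbour is compound 2, with a 3.0-fold lower number from compound 1 to compound 2 (0.48 log units; beyond the scatter); the furthest is compound 3, with a 6.7-fold higher number from compound 1 to compound 3 (0.82 log units; beyond the scatter). Compound 2 and compound 3 are separated by a 20-fold higher number from compound 2 to compound 3 (1.30 log units; beyond the scatter).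

Compound 4 `Cc1ccc(S(=O)(=O)c2cc3cnc(Nc4cnc5c(c4)CC(=O)N5)nc3n(C)c2=O)cc1` has not yet been measured. It differs from compound 1 in this way: a group of 10 heavy atoms (7 carbon, 2 nitrogen, 1 oxygen; one five-membered non-aromatic ring with 1 hetero atom, one six-membered aromatic ring with 1 hetero atom) in place of a group of 9 heavy atoms (8 carbon, 1 nitrogen; one five-membered aromatic ring with 1 hetero atom, one six-membered aromatic ring of carbon only), on a nitrogen on an aromatic ring.

For the measured compounds named here, none of the measured steps touches this place. All three concern the group carried on the other side of the shared core, where the sulfonyl-bearing aryl groups and the carbamoyl group were exchanged, and the group on the nitrogen of the aromatic ring is the same in compounds 1, 2 and 3. The data therefore give no direct guide to the direction or size of this change, and the expectation must rest on compound 1 alone, allowing a wide range in either direction.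

Compound 4 is estimated at 1000 nM (range 250 nM to 4000 nM) in this assay, meaning an expected step of a 1.3-fold higher number from compound 1 to compound 4 (0.12 log units; within the scatter).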

Compound 4, half-maximal inhibitory concentration: 15000 nM
Beside the measured number, compound 4's estimate is 15-fold (1.18 log units) below it; measured number above the stated range.
By their numbers in this assay, from the lowest: compound 2; then compound 1; then compound 3; then compound 4.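

In this assay, for the compounds shown here, the group with the five-membered non-aromatic ring in place of 1H-indol-5-yl gives a 20-fold higher number from compound 1 to compound 4 (1.30 log units; beyond the scatter), so this place on a nitrogen on an aromatic ring, held constant in the earlier compounds, proves highly sensitive to the group it carries. The entering group differs from 1H-indol-5-yl in several counted features at once, including its ring types and its two hydrogen-bond acceptors, and this single step cannot show which of them goes with the higher number. Nothing available here accounts for the size of the step.

On these data alone, it remains open whether the same exchange has a comparable effect when the other side of the shared core carries the (4-hydroxyphenyl)sulfonyl group of compound 2. As far as these compounds go, how a plain phenyl or a pyridine ring would fare at this place also remains open, and either could help separate the contributions of the ring nitrogen and the carbonyl.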